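Trifluorophenyl in place of methylphenyl on the benzylamine arm

This account rests on a few compounds, and the source may have more. Where it says the series, first, only, none or still open, it means among the compounds named here.

For the measured compounds named here, compound 2 `Cc1ccc(CNc2ncnc3c2ncn3[C@@H]2O[C@H](CO)[C@@H](O)[C@H]2O)cc1` is the weaker of the two measured members that share the core of compound 1 `OC[C@H]1O[C@@H](n2cnc3c(NCc4cccc(F)c4)ncnc32)[C@H](O)[C@@H]1O`. In a functional assay on K562 cells (Homo sapiens) for antiproliferative activity, with a stated time of 72 h (a lower number here means a stronger inhibitor, a higher number a weaker inhibitor), compound 1 gives 7600 nM. For compound 2 this assay reports only a limit, > 166000 nM. Compound 3 `OC[C@H]1O[C@@H](n2cnc3c(NCc4cc(F)cc(F)c4)ncnc32)C(O)C1O` also reaches only a limit in this assay, > 166000 nM. Compound 4 `OC[C@H]1O[C@@H](n2cnc3c(NCc4ccc(F)c(F)c4F)ncnc32)[C@H](O)[C@@H]1O` differs from compound 2 by 2,3,4-trifluorophenyl in place of 4-methylphenyl on a saturated chain carbon bound to a nitrogen on an aromatic ring. Going by the values given here, the single step that bears on this change, an at least 21-fold higher number from compound 1 to compound 2 (1.33 log units; beyond the scatter), runs opposite to the direction now taken, since a fluorinated ring returns; compound 3, with its 3,5-difluorophenyl, nevertheless sits at the limit of > 166000 nM in this assay, at which 2 of the 3 values shown sit. A number below the limit is expected for compound 4, the step of an at least 2.7-fold lower number from compound 2 to compound 4 (0.44 log units; beyond the scatter), with wide uncertainty. Compound 4 is estimated at 60000 nM, between 8000 nM and 166000 nM.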

Compound 4, half-maximal inhibitory concentration: > 166000 nM
Compound 4: only a limit was reported (the forecaster's own chance of this, stated with the estimate: 50%); at least 2.7-fold (0.44 log units) between middle value and limit.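

In this assay, 2,3,4-trifluorophenyl gives an at least 21-fold higher number from compound 1 to compound 4 (1.33 log units; beyond the scatter), so fluorine on the phenyl ring does not by itself preserve the activity of compound 1. The step from compound 2 to compound 4 cannot be read, as both values are limits. Only compound 1, with 3-fluorophenyl, gives a measured number, and compound 4 now joins the other compounds at the limit: the limit of > 166000 nM in this assay, at which 3 of the 4 values shown sit.

Which feature of 3-fluorophenyl matters remains open. Plain phenyl, 3-chlorophenyl or 3-methoxyphenyl on this arm would help to show this.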